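The source may report more compounds than this note shows. Statements on the series, on what has been measured and on what is new or still open speak of the compounds shown alone.

Series notes, ester chain on the piperazine side.

Measured so far in a functional assay on A549 cells (Homo sapiens) for cytotoxicity, read by MTT assay, with a stated time of 24 h, tested at 60 uM; on this read-out higher numbers stand for a weaker effect at the one concentration tested and lower numbers for a stronger effect:
compound 1, `CCOC(=O)CCC(=O)N1CCN(CCCOc2cc3c(Nc4ccc(F)c(Cl)c4)ncnc3cc2OC)CC1`, gives 61.6%.
compound 2, `CCCOC(=O)CCC(=O)N1CCN(CCCOc2cc3c(Nc4ccc(F)c(Cl)c4)ncnc3cc2OC)CC1`, gives 70.4%.
compound 3, `CCCCCCCCCCCCCCCOC(=O)CCC(=O)N1CCN(CCCOc2cc3c(Nc4ccc(F)c(Cl)c4)ncnc3cc2OC)CC1`, gives 81.6%.

Not yet measured: compound 4, `CCCCCCCCCCCCCCCCOC(=O)CCC(=O)N1CCN(CCCOc2cc3c(Nc4ccc(F)c(Cl)c4)ncnc3cc2OC)CC1`.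

From compound 1 to compound 2 the change is methyl in place of hydrogen on a saturated chain carbon, two bonds along the chain from an oxygen next to a carbonyl group; the step is a number 8.8 percentage points higher from compound 1 to compound 2 (within the scatter). The next lengthening gives a number 11.2 percentage points higher from compound 2 to compound 3 (beyond the scatter), which leaves compound 3 with the highest number of the three. From compound 3 to compound 4 the change is methyl in place of hydrogen on a saturated chain carbon, ten or more bonds along the chain from an oxygen next to a carbonyl group. This is the same kind of change as from compound 1 to compound 2, but not at the same place: the methyl enters the chain at a different point in each case, as the two differences state. The difference between the core of compound 1 and that of compound 3 is not broken down here. For compound 4 the expected step is a number 2.4 percentage points higher from compound 3 to compound 4 (within the scatter), because the earlier step of a number 8.8 percentage points higher from compound 1 to compound 2 (within the scatter) lay within the scatter. The estimate for compound 4 in this assay is 84%, with a range from 74% to 94%.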

Compound 4, a percentage reported as activity, at one concentration (the size of the read-out at that concentration, not a potency): 80%
For compound 4 the middle estimate is 4 percentage points above the measured one, within the range that was stated.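

In this assay, methyl in place of hydrogen on a saturated chain carbon, ten or more bonds along the chain from an oxygen next to a carbonyl group, gives a number 1.6 percentage points lower from compound 3 to compound 4 (within the scatter). Set beside the earlier methyl step on the other core, this step does not separate from it: the same change on two cores in this assay, a number 8.8 percentage points higher (within the scatter) from compound 1 to compound 2 and a number 1.6 percentage points lower (within the scatter) from compound 3 to compound 4, 10.4 percentage points apart, within the scatter of two such steps

Within this pair of cores, then, carrying the methyl change from one to the other shows no difference that can be read, but this does not establish that the change has the same effect on both, as each step rests on a single pair of compounds, neither step exceeds the scatter, and the methyl enters at a different point of the chain in each.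

The compounds shown leave open how a carboxylic acid or an amide in place of the ester would read in this assay. Also open, from the compounds shown here alone, are a branched chain such as isopropyl and the chain lengths from butyl to dodecyl.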